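Chloro for Methyl on Two Different Cores

The compounds below may be only part of what the source reports. "The series", "measured", "known", "first", "only" and "open" are said of these compounds alone.

Measured compounds:
compound 1, `Cc1ccc(-c2cc(/N=C/N(C)C)n(-c3ccc(Br)cc3)n2)cc1`: > 100000 nM, a limit of the assay
compound 2, `CN(C)/C=N/c1cc(-c2ccc(Cl)cc2)nn1-c1ccc(Br)cc1`: 84900 nM
compound 3, `Cc1ccc(-c2nn(-c3cccc(Cl)c3)c(N)c2C=O)cc1`: 86300 nM

In a functional assay on Jurkat cells (Homo sapiens) for inhibition, read by MTT assay, with a stated time of 72 h (on this read-out higher numbers stand for weaker inhibition of growth and lower numbers for stronger inhibition of growth), compound 1 reaches only a limit of the assay, (the limit of > 100000 nM in this assay, at which 1 of the 3 values shown sits). Compound 2 gives 84900 nM. The change between them is chloro in place of methyl on an aromatic carbon, and the step it made is an at least 1.1-fold lower number from compound 1 to compound 2 (0.07 log units; that floor lies within the scatter), a floor that sits inside the usual scatter of such measurements.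

Compound 3 gives 86300 nM in this assay. Compound 3 and compound 1 have different cores, and how the two cores differ is not broken down here. Compound 4, `Nc1c(C=O)c(-c2ccc(Cl)cc2)nn1-c1cccc(Cl)c1`, has not yet been measured. It differs from compound 3 by chloro in place of methyl on an aromatic carbon, the same change that turns compound 1 into compound 2, on a ring described in the same words in both pairs.

Because the measured instance of this change, an at least 1.1-fold lower number from compound 1 to compound 2 (0.07 log units; that floor lies within the scatter), gave only a floor lying within the scatter, the step from compound 3 to compound 4 is expected to be small, a 1.2-fold lower number from compound 3 to compound 4 (0.09 log units; within the scatter). Compound 4 is therefore estimated to give 70000 nM in this assay, with an expected range from 30000 nM to 150000 nM, and there is a fair chance that the assay again reports only a limit for compound 4.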

Compound 4, concentration for 50% growth inhibition: 78900 nM
Beside the measured number, compound 4's estimate is 1.1-fold (0.05 log units) below it; low and high end bracket the measured number.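

On the core of compound 3 in this assay, replacing 4-methylphenyl with 4-chlorophenyl gives a 1.1-fold lower number from compound 3 to compound 4 (0.04 log units; within the scatter), so the two values stay within the scatter of each other and the change shows no measurable effect on this core. Set beside the earlier case, the comparison reads: the same change on two cores in this assay, an at least 1.1-fold lower number (0.07 log units; that floor lies within the scatter) from compound 1 to compound 2 and a 1.1-fold lower number (0.04 log units; within the scatter) from compound 3 to compound 4; the limit leaves it open whether they differ The value of compound 1, > 100000 nM, is a limit of the assay, so the earlier step is only a floor, and the two pairs show neither that the change has the same size on both cores nor that its size differs between them.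

The compounds shown leave open whether another group at the place held by methyl and chloro, such as methoxy, a carboxylic acid or a longer chain like propyl, would give a step beyond the scatter in this assay. Also open, on these data alone, is how the same exchange of methyl for chloro would read on a core whose compounds give far lower numbers in this assay, where a step could be measured on both sides without a limit.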